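The compounds below may be only part of what the source reports. "The series", "measured", "known", "first", "only" and "open" are said of these compounds alone.

Compound 1 `Cn1cc(-c2cnc(NCc3c(F)ccc4c3CCO4)c3cn[nH]c(=O)c23)cn1`: 21 mL.min-1.g-1
Compound 2 `CN(c1ccn(C)n1)c1cnc(NCc2c(F)ccc3c2CCO3)n2cnnc12`: 11 mL.min-1.g-1

Both numbers come from an ADME assay on microsomes from liver (Homo sapiens) for metabolic stability, read by LC-MS, using NADPH, with stated times of 5 min and 30 min, tested at 1 uM; on this read-out higher numbers stand for fast clearance and lower numbers for slow clearance. Compound 2 and compound 1 lie within the scatter of each other, so on these two numbers neither stands apart.

Compound 3 `CN(c1cccnc1)c1cnc(NCc2c(F)ccc3c2CCO3)n2cnnc12` differs from compound 2 in one place: pyridin-3-yl in place of 1-methyl-1H-pyrazol-3-yl on a nitrogen on an aromatic ring. Here pyridin-3-yl stands in place of 1-methyl-1H-pyrazol-3-yl on a nitrogen on an aromatic ring. Among the measured compounds shown here, no measured pair shows this exchange, so the expectation starts from compound 2 at 11 mL.min-1.g-1 and has no measured step to lean on. No step beyond the scatter is expected, with a slight lean towards a higher number. The estimated change is a 1.3-fold higher number from compound 2 to compound 3 (0.10 log units; within the scatter). For compound 3 the expected value in this assay is 14 mL.min-1.g-1, with an estimated range of 7 mL.min-1.g-1 to 28 mL.min-1.g-1.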

Compound 3, intrinsic clearance in microsomes: 80 mL.min-1.g-1
Beside the measured number, compound 3's estimate is 5.7-fold (0.76 log units) below it; measured number outside the range, above it.
By their numbers in this assay, from the lowest: compounds 2 and 1 (each within the scatter of the next); then compound 3.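

In this assay, among the compounds shown here, the group on a nitrogen on an aromatic ring turns out to be a sensitive position, which the earlier compounds could not show because they offered no step there: pyridin-3-yl in place of 1-methyl-1H-pyrazol-3-yl gives a 7.3-fold higher number from compound 2 to compound 3 (0.86 log units; beyond the scatter) as a single exchange. The leaving and entering groups have the same heavy-atom count, so this step comes with no change in that count, only with a change from a five-membered ring with 2 hetero atoms to a six-membered ring with 1. Nothing at hand accounts for the size of this step.

Still open, going by these compounds, is whether the higher number goes with the six-membered ring as such or with the particular ring nitrogen. A phenyl ring or a saturated amine such as morpholine on the same nitrogen would help to separate these readings.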